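Swapping an Ester for an Aminomethyl Group

The compounds below may be only part of what the source reports. "The series", "measured", "known", "first", "only" and "open" are said of these compounds alone.

Four compounds sharing one core are compared in a functional assay on PC-6 cells (Homo sapiens) for cytotoxicity, read by MTT assay, with a stated time of 3 days; on this read-out lower numbers stand for stronger inhibition and higher numbers for weaker inhibition. Compound 1, with the structure `CC(C)(C)c1cc2c(N/N=C/c3ccc(O)cc3)ncnc2s1`, reaches only the limit of the assay, reported as > 10 ug/mL. Compound 2, with the structure `CN1Cc2ccc(/C=N/Nc3ncnc4sc(C(C)(C)C)cc34)cc2C1`, gives 0.05 ug/mL in this assay. Compound 3, with the structure `COC(=O)c1ccc(/C=N/Nc2ncnc3sc(C(C)(C)C)cc23)cc1`, has no number in this assay, its entry being "not determined" (no result reported), so it stands nowhere on the scale. Among the values shown, the only other entry besides the single number is that of compound 1, namely (the limit of > 10 ug/mL in this assay, at which 1 of the 3 values shown sits).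

Compound 4, with the structure `CC(C)(C)c1cc2c(N/N=C/c3ccc(CN)cc3)ncnc2s1`, is the compound still to be measured. It differs from compound 3 in one place: aminomethyl in place of methoxycarbonyl on an aromatic carbon.

For the measured compounds named here, with no number for compound 3, no step can be computed here, and the expectation for compound 4 rests on compound 1 and compound 2 alone. Going by the values given here, the single measured number and the limit lie far apart, beyond the usual scatter, so a large difference between members is possible.

Because compound 2 gives 0.05 ug/mL in this assay, compound 4 is expected to give about 0.1 ug/mL, estimated within the range 0.02 ug/mL to 1 ug/mL.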

Compound 4, half-maximal inhibitory concentration: 0.214 ug/mL
Estimate against measurement, compound 4: 2.1-fold (0.33 log units) below; low and high end bracket the measured number.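

Setting aminomethyl in place of hydroxy on an aromatic carbon, para to a large group, gives in this assay an at least 46-fold lower number from compound 1 to compound 4 (1.66 log units; beyond the scatter). For the compounds shown here, this is the first comparison between two compounds that differ in one place only, and it shows that the group at this position can by itself separate a compound at the limit of the assay from one with a measurable number. The true size of this step remains unknown, and it can only be stated as a minimum, because compound 1 stands at a limit rather than at a number: the limit of > 10 ug/mL in this assay, at which 1 of the 4 values shown sits.

The step between compound 3 and compound 4 cannot be read: compound 3 carries no result, so the shown data say nothing about how methoxycarbonyl compares with aminomethyl. Also open, going by these compounds, is whether the lower number belongs to aminomethyl specifically or would also appear with a longer chain such as aminoethyl, with a dimethylaminomethyl group, or with a carboxylic acid at the same place.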